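This account rests on a few compounds, and the source may have more. Where it says the series, first, only, none or still open, it means among the compounds named here.

In a functional assay on HCT-116 cells (Homo sapiens) for antiproliferative activity, read by MTT assay, with a stated time of 72 h (a higher number here means a weaker inhibitor, a lower number a stronger inhibitor), compound 2 `O=C(O)c1cccc(NCCOc2ccc3cc2COC/C=C/COCc2cccc(c2)-c2ccnc(n2)N3)c1` gives 59200 nM and compound 1 `O=C(O)c1ccc(OCCOc2ccc3cc2COC/C=C/COCc2cccc(c2)-c2ccnc(n2)N3)cc1` gives 29700 nM, with a 2.0-fold higher number from compound 1 to compound 2 (0.30 log units; within the scatter) separating them. Compound 3 `O=C(O)CCCCCCC(=O)Nc1ccc(NCCOc2ccc3cc2COC/C=C/COCc2cccc(c2)-c2ccnc(n2)N3)cc1` reads lower, at 2700 nM on the same scale. Compound 4 `O=C(O)CCCCCCCOc1ccc2cc1COC/C=C/COCc1cccc(c1)-c1ccnc(n1)N2` differs from compound 2 by 5-carboxypentyl in place of (3-carboxyphenyl)amino on a saturated chain carbon, two bonds along the chain from an oxygen on an aromatic ring in one place: 5-carboxypentyl in place of (3-carboxyphenyl)amino on a saturated chain carbon, two bonds along the chain from an oxygen on an aromatic ring. For the measured compounds named here, no measured step tests this swap directly, and the only one available exchanges one carboxyphenyl-bearing group for another. Compound 3, which also ends in an open carbon chain carrying a carboxylic acid, gives 2700 nM and so hints at a lower number. The expected change is a 3.0-fold lower number from compound 2 to compound 4 (0.47 log units; beyond the scatter) by estimate, though with real uncertainty. Compound 4 is expected at an estimated 20000 nM with 6000 nM to 60000 nM as the likely span.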

Compound 4, half-maximal inhibitory concentration: 8040 nM
Compound 4: the middle estimate sits 2.5-fold (0.40 log units) above what was measured; the measured number falls inside the stated range.
By their numbers in this assay, from the lowest: compound 3; then compound 4; then compounds 1 and 2 (each within the scatter of the next).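

In this assay the 5-carboxypentyl group, which has no ring, gives a 7.4-fold lower number from compound 2 to compound 4 (0.87 log units; beyond the scatter) and a 3.7-fold lower number from compound 1 to compound 4 (0.57 log units; beyond the scatter) at this place on the chain. For the compounds shown here, the swap between the two ring-bearing groups stayed within the scatter, so this is the first single change here to move the number beyond it. Nothing available explains the shift. Every compound shown ends in a carboxylic acid, so a methyl ester or a hydroxamic acid at the chain end would test that group, and a longer chain would test the length.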